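The compounds below may be only part of what the source reports. "The series", "measured", "known", "first", "only" and "open" are said of these compounds alone.

compound 1 (`CCOC(=O)c1cc(CCCOc2ccc(-c3noc(C(F)(F)F)n3)cc2OC)on1`): > 100000 nM (a limit)
compound 2 (`CCOC(=O)c1cc(CCCOc2ccc(-c3noc(C(F)(F)F)n3)cc2F)on1`): 60200 nM

In an ADME assay on HeLa cells (Homo sapiens) for cytotoxicity, read by crystal violet staining, with a stated time of 72 h (a lower number here means that less compound is tolerated, a higher number that more compound is tolerated), compound 1 has no number, only a limit (the limit of > 100000 nM in this assay, at which 1 of the 2 values shown sits). Compound 3 (`CCOC(=O)c1cc(CCCOc2c(OC)cc(-c3noc(C(F)(F)F)n3)cc2[N+](=O)[O-])on1`) departs from compound 1 by one change (nitro in place of hydrogen on an aromatic carbon): nitro in place of hydrogen on an aromatic carbon, meta to a methoxy group. Among the compounds with values here, the only measured step (an at least 1.6-fold lower number from compound 1 to compound 2 (0.22 log units; that floor lies within the scatter)) is a different change, fluoro in place of methoxy, and its floor lies within the scatter, so it bears on this case only loosely. Compound 2 does give a number (60200 nM), so a change to compound 1 can yield a measurable value. At most a modest step towards a lower number is therefore expected in this assay, possibly none beyond the scatter, and another limit remains quite possible. The expected change is an at least 1.3-fold lower number from compound 1 to compound 3 (0.12 log units; that floor lies within the scatter) as a working figure. For compound 3 the estimated value is 75000 nM, within an expected range of 30000 nM to 150000 nM.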

Compound 3, half-maximal cytotoxic concentration: > 100000 nM
Compound 3 gave a limit, no number; the forecaster's own chance of this, stated with the estimate: 40%; middle value at least 1.3-fold (0.12 log units) from the limit.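

In this assay, compound 1 and compound 3 each give only a limit, so no step between them can be read: the limit of > 100000 nM in this assay, at which 2 of the 3 values shown sit.

The compounds shown leave open whether nitro in place of hydrogen on an aromatic carbon shifts the number at all in this assay.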